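The compounds below may be only part of what the source reports. "The series", "measured", "known", "first", "only" and "open" are said of these compounds alone.

Compound 1 `O=c1[nH]cc(S(=O)(=O)Nc2ccccc2-c2cn(-c3ccccc3)nn2)c(=O)[nH]1`: in a functional assay on HepG2 cells (Homo sapiens) for antiproliferative activity, read by MTT assay, with a stated time of 24 h (on this read-out lower numbers stand for stronger inhibition and higher numbers for weaker inhibition), compound 1 gives 6160 nM.
Compound 2 `O=c1[nH]cc(S(=O)(=O)Nc2ccccc2-c2cn(-c3ccc(F)cc3)nn2)c(=O)[nH]1`: in this assay compound 2 gives only a limit, > 20000 nM.

Compound 2 therefore stands at the weaker end of the two numbers shown, and since its value is a limit of this assay and not a number, only a range is known for it. Among the compounds with values here, the single measured step, an at least 3.2-fold higher number from compound 1 to compound 2 (0.51 log units; beyond the scatter), turned on a fluoro group and ended at the limit of > 20000 nM in this assay, at which 1 of the 2 values shown sits. Compound 3 `O=c1[nH]cc(S(=O)(=O)Nc2ccccc2-c2cn(-c3cccc(Cl)c3)nn2)c(=O)[nH]1` differs from compound 2 in the aryl group on the aromatic nitrogen: 3-chlorophenyl in place of 4-fluorophenyl on an aromatic nitrogen. Within the data shown here, no measured pair contains a 3-chlorophenyl group, so the one measured step bears on this change only indirectly: it shows that a halogen on that phenyl ring did not help, but it does not show whether a chloro group, placed as in compound 3, behaves like the fluoro group or differently. Compound 3 is thus expected to remain near the limit, with a step of a number no higher from compound 2 to compound 3 (the limit leaves the size open) expected. The estimated value for compound 3 is 20000 nM, with a range from 6000 nM to 60000 nM.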

Compound 3, half-maximal inhibitory concentration: 2460 nM
Estimate against measurement, compound 3: 8.1-fold (0.91 log units) above, outside the stated range (below it).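

Chloro in place of hydrogen on the phenyl ring gave a 2.5-fold lower number from compound 1 to compound 3 (0.40 log units; beyond the scatter), while fluoro in place of hydrogen gave an at least 3.2-fold higher number from compound 1 to compound 2 (0.51 log units; beyond the scatter), so in this assay a halogen on this ring does not act in one direction only: compound 3 goes with a lower number and compound 2 with a higher one. The exchange of 4-fluorophenyl for 3-chlorophenyl on the aromatic nitrogen gave an at least 8.1-fold lower number from compound 2 to compound 3 (0.91 log units; beyond the scatter), which shows that the outcome at this position depends on which substituted phenyl group is present, and not merely on whether a halogen is there. The full size of that step stays open because compound 2 gives a limit of the assay and not a number: the limit of > 20000 nM in this assay, at which 1 of the 3 values shown sits.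

The exchange changes both the halogen and its place on the ring, and the three compounds do not separate these two changes, so it remains unknown which of them accounts for the difference. They also leave open how the same position would respond to a bromo group, a methoxy group or an amine on the phenyl ring.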